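This account rests on a few compounds, and the source may have more. Where it says the series, first, only, none or still open, it means among the compounds named here.

Measured compounds:
compound 1 `COc1cc(-c2cc(/C=C/C(=O)c3ccc(Cl)c(Cl)c3)[nH]n2)cc(OC)c1OC`: 95%
compound 2 `COc1ccc(-c2cc(/C=C/C(=O)c3cc(OC)c(OC)c(OC)c3)[nH]n2)cc1OC`: 82%

In a functional assay on BT-549 cells (Homo sapiens) for cytotoxicity, read by sulforhodamine B assay, with a stated time of 48 h, tested at 0.1 uM (a lower number here means a stronger effect, a higher number a weaker effect of the compound at the concentration tested), compound 1 gives 95%, the higher of the two numbers; compound 2 gives 82%, lower by a margin beyond the scatter.

Compound 3 `COc1cc(-c2cc(/C=C/C(=O)c3ccc(F)c(F)c3)[nH]n2)cc(OC)c1OC` is not yet measured. It differs from compound 1 in one place: 3,4-difluorophenyl in place of 3,4-dichlorophenyl on a carbonyl carbon. Within the data shown here, no measured pair shows a change of this kind, so the size of the step cannot be read from the series. In this assay a step no larger than the scatter is expected, in no clear direction, because the shared core and the rest of compound 1 are kept and compound 1 gives 95% there.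

Compound 3 is therefore expected to give 94%, within a range of 82% to 104%. That estimate means a step of a number 1 percentage points lower from compound 1 to compound 3 (within the scatter).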

Compound 3, a percentage reported as activity, at one concentration (the size of the read-out at that concentration, not a potency): 105%
Beside the measured number, compound 3's estimate is 11 percentage points below it; the whole stated range lies below it.
By their numbers in this assay, from the lowest: compound 2; then compounds 1 and 3 (each within the scatter of the next).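

In this assay, 3,4-difluorophenyl in place of 3,4-dichlorophenyl on a carbonyl carbon gives a number 10 percentage points higher from compound 1 to compound 3 (within the scatter), so this exchange of one halogen pair for another does not separate the two compounds at the single concentration tested. The series thus gains its first one-place comparison, and at this place the read-out holds across the change. Nothing available accounts for this result.

On these data alone, what an amine or a carboxylic acid on that phenyl would do remains open. So does whether compound 1 and compound 3 would separate at other concentrations.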